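Thiazolyl in place of the small sulfur group on compound 2

The compounds below may be only part of what the source reports. "The series", "measured", "known", "first", "only" and "open" are said of these compounds alone.

Of the compounds shown here, three have been read in a physicochemical assay for inhibition, read by colorimetric assay, tested at 1 mg/mL; a lower number here means less inhibition, a higher number more inhibition at the concentration tested (going by the name of the read-out). Compound 2 `CCN1C/C(=C\c2ccc(OC)cc2)C2=NN(C(N)=S)C(c3ccc(OC)cc3)C2C1` gives 88.2%, the highest of the three. Compound 1 `COc1ccc(/C=C2\CN(C)CC3C2=NN(c2nc(-c4ccc(Cl)cc4)cs2)C3c2ccc(OC)cc2)cc1` gives 69.6%, and compound 3 `COc1ccc(/C=C2\CCC3C2=NN(c2nc(-c4ccc(Cl)cc4)cs2)C3c2ccc(OC)cc2)cc1` gives 27.5%; both lie well beneath compound 2, beyond the scatter.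

Compound 4 `CCN1C/C(=C\c2ccc(OC)cc2)C2=NN(c3nc(-c4ccccc4)cs3)C(c3ccc(OC)cc3)C2C1` is not yet measured. The change from compound 2 is a group of 11 heavy atoms (9 carbon, 1 nitrogen, 1 sulfur; one five-membered aromatic ring with 2 hetero atoms, one six-membered aromatic ring of carbon only) in place of a group of 3 heavy atoms (1 carbon, 1 nitrogen, 1 sulfur; no ring), on an amine nitrogen in a ring. Compound 1 carries a related aromatic group on the same ring nitrogen and sits under compound 2, so a drop of moderate size is expected, a number 23.2 percentage points lower from compound 2 to compound 4 (beyond the scatter), though the differing saturated ring in compound 1 leaves this uncertain. Compound 4 is estimated at 65% in this assay, within 45% to 85%.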

Compound 4, a percentage reported as inhibition, at one concentration (the size of the read-out at that concentration, not a potency): 60.5%
Compound 4: middle estimate off by 4.5 percentage points, on the high side; the range from low to high includes it.
By their numbers in this assay, from the lowest: compound 3; then compounds 4 and 1 (each within the scatter of the next); then compound 2.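

For the compounds shown here, putting 4-phenyl-1,3-thiazol-2-yl on this amine nitrogen, in place of the group of 3 heavy atoms with no ring, gives in this assay a number 27.7 percentage points lower from compound 2 to compound 4 (beyond the scatter), the first reading of this change with the rest of the compound held constant. Inhibition falls but does not vanish: compound 4 still gives 60.5%. No measurement available here bears on the reason for this step.

On these data alone, whether an acetyl group or a simple amine-bearing chain on this nitrogen would read nearer to compound 2 stays open. Also open, as far as these compounds go, is the size of the same change on the core of compound 1.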